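Tert-butyl for trifluoromethyl on an aromatic carbon

This account rests on a few compounds, and the source may have more. Where it says the series, first, only, none or still open, it means among the compounds named here.

Compound 1 `Cc1cc(NC(=O)Nc2ccccc2C(F)(F)F)c2ccccc2n1` — > 25000 nM
Compound 2 `Cc1cc(NC(=O)Nc2ccc(N(C)C)cc2)c2ccccc2n1` — > 25000 nM
Compound 3 `Cc1cc(NC(=O)Nc2cccc(C(C)(C)C)c2)c2ccccc2n1` — > 25000 nM

The three compounds above share one core and differ only in the substitution of the aryl ring on the far side of the urea-like linker. All were tested in an ADME assay on HepG2 cells (Homo sapiens) for cytotoxicity, with a stated time of 72 h; on this read-out lower numbers stand for an effect already at smaller amounts and higher numbers for an effect only at larger amounts of compound. In this assay compound 1 gives > 25000 nM, which is a limit of the assay and not a number. Compound 2 likewise sits at a limit, > 25000 nM. Compound 3 also returns a limit, > 25000 nM. Going by the values given here, compound 1 therefore cannot be ranked against the others; it simply stands at the limit of > 25000 nM in this assay, at which 3 of the 3 values shown sit, and no measured step between any two compounds is available.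

Compound 4 `Cc1cc(NC(=O)Nc2ccccc2C(C)(C)C)c2ccccc2n1` is the untested member. It differs from compound 1 by tert-butyl in place of trifluoromethyl on an aromatic carbon. Among the compounds with values here, since every value so far sits at the same limit, the step from compound 1 to compound 4 is expected to be a step that the limit leaves unreadable from compound 1 to compound 4, meaning none beyond the scatter. Compound 4 is thus expected to give about 30000 nM in this assay, with a likely range from 12000 nM to 80000 nM.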

Compound 4, half-maximal effective concentration: > 25000 nM
Compound 4 was reported as a limit (the forecaster's own chance of this, stated with the estimate: 80%); the middle value does not contradict the limit.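

In this assay compound 4 gives > 25000 nM, which is a limit of the assay and not a number. Going by these compounds alone, no step from compound 1 to compound 4 can be read, because both stand at the same limit: the limit of > 25000 nM in this assay, at which 4 of the 4 values shown sit. The compounds shown leave open whether tert-butyl in place of trifluoromethyl on an aromatic carbon changes the read-out at all.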